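Moving a Fluorine Around the Aryl Ring of a Succinimide Amide

This account rests on a few compounds, and the source may have more. Where it says the series, first, only, none or still open, it means among the compounds named here.

Measured so far:
- compound 1, `CCC(C(=O)N1CCN(c2ccccc2Cl)CC1)N1C(=O)CCC1=O`, 50%
- compound 2, `CCC(C(=O)N1CCN(c2cccc(F)c2)CC1)N1C(=O)CCC1=O`, 75%
- compound 3, `CC(C(=O)N1CCN(c2ccccc2F)CC1)N1C(=O)CCC1=O`, 100%

All three compounds share one core and were tested in a functional assay on the whole organism (strain Swiss) with Mus musculus as the target, in the maximal electroshock model, with a stated time of 0.25 h, at a dose of 300 mg/kg by the intraperitoneal route; on this read-out higher numbers stand for a stronger effect at the one dose given and lower numbers for a weaker effect. Compound 3 gives 100%, the highest of the three numbers, and its gaps to compound 2 and to compound 1 both lie beyond the scatter. For the measured compounds named here, only one single-point step is available among the measured compounds: a number 25 percentage points higher from compound 1 to compound 2 (beyond the scatter), which swaps 2-chlorophenyl for 3-fluorophenyl. Going by the values given here, compound 1 and compound 3 differ in two places, so their values show only that compound 3 stands well above compound 1.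

Compound 4, `CC(C(=O)N1CCN(c2ccc(F)cc2)CC1)N1C(=O)CCC1=O`, has not yet been measured. The change from compound 3 is 4-fluorophenyl in place of 2-fluorophenyl on an amine nitrogen in a ring: the same atoms, joined differently, with the fluorine moving on the phenyl ring. Among the compounds with values here, no measured step covers this exact move; the step from compound 1 to compound 2 changed both the halogen and its position, so it offers only a loose hint that the ring substituent matters. Given that compound 3 already sits at the top of this read-out, a step of a number 25 percentage points lower from compound 3 to compound 4 (beyond the scatter) in this assay is expected, toward a somewhat lower value. For compound 4 the expected result in this assay is 75%, with a range from 50% to 100%.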

Compound 4, a percentage reported as activity, at one dose (the size of the read-out at that dose, not a potency): 100%
For compound 4 the middle estimate is 25 percentage points below the measured one; the measured number falls inside the stated range.
By their numbers in this assay, from the lowest: compound 1; then compound 2; then compounds 3 and 4 (each within the scatter of the next).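

In this assay, replacing 2-fluorophenyl with 4-fluorophenyl on the amine nitrogen in the ring gives no change at the digits printed from compound 3 to compound 4 (within the scatter). This is the first step shown that changes only where the fluorine sits, as the earlier step changed both the halogen and its position, and here the relocation leaves the read-out unmoved at this one dose. No measurement on hand explains why these two fluorophenyl groups give the same result.

From the compounds shown here alone, the read-out reflects the size of the effect at a single dose rather than potency, so it remains open whether compound 3 and compound 4 would still match at lower doses. Also open, going by these compounds, is whether a larger group such as trifluoromethyl or methoxy, in place of the fluorine on this phenyl ring, would hold the effect at this level.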